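This account rests on a few compounds, and the source may have more. Where it says the series, first, only, none or still open, it means among the compounds named here.

Measured compounds:
Compound 1 `COC(=O)C1=C(C)N=C(C)/C(=C(/O)OC)C1c1cccc(N/C(=N/CCNC2CCN(c3ccccc3C#N)CC2)NC#N)c1`: 3 nM
Compound 2 `COC(=O)C1=C(C)N=C(C)/C(=C(/O)OC)C1c1cccc(N/C(=N/CCNC2CCN(c3ccccc3OC)CC2)NC#N)c1`: 4 nM
Compound 3 `COC(=O)C1=C(C)N=C(C)/C(=C(/O)OC)C1c1cccc(NC(=O)NCCNC2CCN(c3ccccc3C#N)CC2)c1`: 3 nM

In an assay on SK-N-MC cells for inhibition of Neuropeptide Y receptor type 1 (Homo sapiens) (on this read-out higher numbers stand for weaker inhibition and lower numbers for stronger inhibition), compound 1 gives 3 nM. Compound 2 carries the change (methoxy in place of cyano on an aromatic carbon), and in this assay compound 2 gives 4 nM. The step is a 1.3-fold higher number from compound 1 to compound 2 (0.12 log units; within the scatter). Compound 3 gives 3 nM, the same number as compound 1 at the digits reported and within the scatter of compound 2; the difference between the core of compound 3 and that of compound 1 is not broken down here.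

Compound 4 `COC(=O)C1=C(C)N=C(C)/C(=C(/O)OC)C1c1cccc(NC(=O)NCCNC2CCN(c3ccccc3OC)CC2)c1` has not yet been measured. It stands to compound 3 as compound 2 stands to compound 1: the change is methoxy in place of cyano on an aromatic carbon, the same change at the same place, this time on the core shared with compound 3. For the measured compounds named here, the only guide to its size is the one measured step, which stayed within the scatter. On that basis the step from compound 3 to compound 4 is expected to be a 1.3-fold higher number from compound 3 to compound 4 (0.12 log units; within the scatter), because the earlier step of a 1.3-fold higher number from compound 1 to compound 2 (0.12 log units; within the scatter) was small and the two cores each gave the same number. Compound 4 is therefore estimated at 4 nM in this assay, with a likely range from 2 nM to 9 nM.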

Compound 4, half-maximal inhibitory concentration: 2 nM
Compound 4: the middle estimate sits 2.0-fold (0.30 log units) above what was measured; the measured number falls inside the stated range.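

In this assay, methoxy in place of cyano on the core of compound 3 gives a 1.5-fold lower number from compound 3 to compound 4 (0.18 log units; within the scatter), a step that lies within the usual scatter of repeated measurements. Set beside the earlier step, the change carries from one core to the other without a difference that can be told apart: the same change on two cores in this assay, a 1.3-fold higher number (0.12 log units; within the scatter) from compound 1 to compound 2 and a 1.5-fold lower number (0.18 log units; within the scatter) from compound 3 to compound 4, 2.0-fold (0.30 log units) apart, within the scatter of two such steps. This shows that, on these two cores and in this one assay, the move from 2-cyanophenyl to 2-methoxyphenyl leaves the number within the scatter, so the two groups can be treated as interchangeable here; it does not show that either group is the better one, it gives the step no reliable direction, and two pairs cannot show that the same would hold on a third core or in another assay.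

The compounds shown leave open whether the number would hold with another group on that aromatic carbon, such as a fluorine, a hydroxyl or an amine, or with no substituent there at all. They also leave open how a longer chain in the linker would act on either core, and whether the cyano and methoxy groups would still match in that setting.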